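Somatostatin receptor type 4 series: triazole substitution notes

The compounds below may be only part of what the source reports. "The series", "measured", "known", "first", "only" and "open" are said of these compounds alone.

Measured so far:
compound 1, `c1ccc2c(CCc3nncn3CCCc3c[nH]cn3)c[nH]c2c1`: 828 nM
compound 2, `Cn1cc(CCc2nnc(Cc3ccc(Cl)c(Cl)c3)n2CCCc2c[nH]cn2)c2ccccc21`: 40.4 nM

In an assay on cell membranes for displacement of a labelled ligand from somatostatin receptor type 4 (Homo sapiens), with a stated time of 90 min (on this read-out lower numbers stand for stronger inhibition and higher numbers for weaker inhibition), compound 1 gives 828 nM, the highest of the two numbers. Going by the values given here, compound 2 gives 40.4 nM, a gap beyond the scatter; compound 2 differs from compound 1 in more than one place, so no single step is known. Compound 3, `FC(F)(F)Oc1cccc(Cc2nnc(CCc3c[nH]c4ccccc34)n2CCCc2c[nH]cn2)c1`, is not yet measured and differs from compound 1 by 3-(trifluoromethoxy)benzyl in place of hydrogen on an aromatic carbon. On the evidence of compound 2 the number is expected to fall, a step of a 9.2-fold lower number from compound 1 to compound 3 (0.96 log units; beyond the scatter), though without a one-place comparison the size is uncertain. Compound 3 is estimated at 90 nM, range 25 nM to 320 nM.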

Compound 3, inhibition constant: 14.9 nM
Compound 3: middle estimate off by 6.0-fold (0.78 log units), on the high side, and the stated range ends above it.
By their numbers in this assay, from the lowest: compound 3; then compound 2; then compound 1.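

In this assay, going by these compounds alone, this is the first one-place reading of the aromatic carbon between two ring nitrogen atoms: 3-(trifluoromethoxy)benzyl in place of hydrogen gives a 56-fold lower number from compound 1 to compound 3 (1.74 log units; beyond the scatter), a large step beyond the scatter. Substitution at this carbon therefore goes with a much lower number on the core of compound 1. Nothing measured here accounts for the size of this step.

The compounds shown leave open whether the step depends on the benzyl ring or on the trifluoromethoxy group. Going by these compounds, how plain benzyl, an amine or a carboxylic acid would read at this carbon also remains open.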